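The source may report more compounds than this note shows. Statements on the series, on what has been measured and on what is new or still open speak of the compounds shown alone.

Measured in a functional assay on HeLa cells (Homo sapiens) for cytotoxicity, read by MTT assay, with a stated time of 72 h; on this read-out lower numbers stand for stronger inhibition and higher numbers for weaker inhibition:
Compound 1 `O=C(Nc1nnc(-c2cccc(O)c2O)s1)c1ccc(Cl)cc1` gives 13000 nM.
Compound 2 `O=C(Nc1nnc(-c2ccc(O)c(O)c2)s1)c1ccc(Cl)cc1` gives 47300 nM.
Compound 3 `CC(=O)Nc1nnc(-c2cccc(O)c2O)s1` gives 177000 nM.

Compounds 1 and 2 are built from the same atoms joined differently; the difference between the two cores is not broken down here. Compound 1 and compound 3 differ in one place, (methyl in place of 4-chlorophenyl on a carbonyl carbon), and in this assay that change gave a 14-fold higher number from compound 1 to compound 3 (1.13 log units; beyond the scatter). Compound 2 sits between compound 1 and compound 3 in this set, and its distance to each of them is beyond the usual scatter.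

Compound 4 `CC(=O)Nc1nnc(-c2ccc(O)c(O)c2)s1` has not been measured yet. It differs from compound 2 by methyl in place of 4-chlorophenyl on a carbonyl carbon, the same change at the same place as the one from compound 1 to compound 3, which is the only other time it occurs among these compounds. Because that earlier change gave a 14-fold higher number from compound 1 to compound 3 (1.13 log units; beyond the scatter), a step of similar size is expected here, namely an 11-fold higher number from compound 2 to compound 4 (1.02 log units; beyond the scatter). Compound 4 is therefore estimated at 500000 nM in this assay, within 180000 nM to 1500000 nM. This rests on a single pair, so the expectation is loose, and the measurement may come back as a limit rather than a number.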

Compound 4, half-maximal inhibitory concentration: 125000 nM
Beside the measured number, compound 4's estimate is 4.0-fold (0.60 log units) above it, and the stated range ends above it.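

In this assay, putting methyl in place of 4-chlorophenyl on the carbonyl carbon gave a 2.6-fold higher number from compound 2 to compound 4 (0.42 log units; beyond the scatter), so the number rose on this core as well. The direction of the change therefore held on both cores, but its size did not carry over: the same change on two cores in this assay, a 14-fold higher number (1.13 log units; beyond the scatter) from compound 1 to compound 3 and a 2.6-fold higher number (0.42 log units; beyond the scatter) from compound 2 to compound 4, 5.2-fold (0.71 log units) apart, beyond the scatter of two such steps. In this small series, a step measured on one core indicated the direction on the other but not how large the step would be, and these two pairs cannot explain the difference or show how a further core would respond.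

As far as these compounds go, only 4-chlorophenyl and methyl appear at this place, so it remains open how a plain phenyl, a longer chain such as butyl, or a group carrying an amine or a carboxylic acid would behave on either core. From the compounds shown here alone, it is also open whether the gap between the two steps would persist in cells other than HeLa.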